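The compounds below may be only part of what the source reports. "The series", "measured", "known", "first", "only" and "open" are said of these compounds alone.

Measured compounds:
Compound 1, `Nc1cccc(/C=C2\SC(=O)N(Cc3cccc(F)c3)C2=O)c1`: in a functional assay on CCRF-CEM cells (Homo sapiens) for cytotoxicity, read by cell counting, with a stated time of 3 days (on this read-out higher numbers stand for weaker inhibition and lower numbers for stronger inhibition), compound 1 gives 250000 nM.
Compound 2, `Nc1ccc(/C=C2\SC(=O)N(Cc3cccc(F)c3)C2=O)cc1`: compound 2 gives 116000 nM.
Compound 3, `C=C(Br)C(=O)Nc1cccc(/C=C2\SC(=O)N(Cc3ccccc3)C2=O)c1`: compound 3 gives 510 nM.

Compound 1 has the highest number of the three, so on this read-out it is the weakest inhibitor of the set. Within the data shown here, the only single-place step measured, a 2.2-fold lower number from compound 1 to compound 2 (0.33 log units; beyond the scatter), moves the amino group on the other ring and is also the smallest gap compound 1 has to any measured compound. Among the measured compounds shown here, compound 3 sits far below it, but it differs from compound 1 in more than one place, so its value shows only that large changes elsewhere can move the number a great deal.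

Compound 4, `Nc1cccc(/C=C2\SC(=O)N(Cc3cccc(Cl)c3)C2=O)c1`, differs from compound 1 by chloro in place of fluoro on an aromatic carbon. For the measured compounds named here, no measured step swaps one halogen for another on that ring, and the one measured step concerns a different ring, so nothing measured bears directly on this change. With no guide pointing either way, a step within the scatter is expected. Compound 4 is therefore expected to give 200000 nM, with a range from 70000 nM to 500000 nM. That amounts to an expected step of a 1.3-fold lower number from compound 1 to compound 4 (0.10 log units; within the scatter).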

Compound 4, half-maximal inhibitory concentration: 195000 nM
Compound 4: the middle estimate sits 1.0-fold (0.01 log units) above what was measured; measured number inside the range.
By their numbers in this assay, from the lowest: compound 3; then compounds 2, 4 and 1 (each within the scatter of the next, the first and the last beyond it).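

Putting chloro in place of fluoro on this aromatic carbon gives a 1.3-fold lower number from compound 1 to compound 4 (0.11 log units; within the scatter) in this assay, so this measurement does not separate the two halogens at this place on the ring. Among these compounds, the only earlier single-place step concerned the amino group on the other ring, and this is the first step to read the halogen-bearing ring itself; unlike that earlier step, it stays within the scatter. No outside evidence bears on this result.

One swap between two halogens leaves open how the number would respond to other groups at this place, such as bromo, methoxy, a nitrile or simply hydrogen. From the compounds shown here alone, it is also open whether the swap would read the same with the amino group placed as in compound 2, or with the amide side chain that compound 3 carries.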